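Inserting a methylene before the pyridine ring

The source may report more compounds than this note shows. Statements on the series, on what has been measured and on what is new or still open speak of the compounds shown alone.

Measured compounds:
- compound 1, `O=C(Cn1c(=O)oc2cc(Cl)ccc21)NCc1cccs1`: 53.6%
- compound 2, `O=C(Cn1c(=O)oc2cc(Cl)ccc21)Nc1ccccc1`: 20.2%
- compound 3, `O=C(Cn1c(=O)oc2cc(Cl)ccc21)Nc1ccccn1`: 43.7%

All three share one core and differ only in the group on the amide-type nitrogen. In an ADME assay on RAW264.7 cells (Mus musculus) for cytotoxicity, read by MTT assay, with a stated time of 72 h, tested at 100 uM (on this read-out higher numbers stand for a stronger effect at the one concentration tested and lower numbers for a weaker effect), compound 3 stands second highest of the three numbers. Its nearest neighbour is compound 1, reached by a number 9.9 percentage points lower from compound 1 to compound 3 (within the scatter), so the two cannot be told apart. Its furthest is compound 2, reached by a number 23.5 percentage points higher from compound 2 to compound 3 (beyond the scatter).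

Compound 4, `O=C(Cn1c(=O)oc2cc(Cl)ccc21)NCc1ccccn1`, is the next step: (pyridin-2-yl)methyl in place of pyridin-2-yl on an amide-type nitrogen. Going by the values given here, the one change is the extra methylene that enters between the amide-type nitrogen and the ring.

Among the compounds with values here, two measured steps bear on this. From compound 1 to compound 2, a (thiophen-2-yl)methyl group gives way to a directly attached phenyl, and a number 33.4 percentage points lower from compound 1 to compound 2 (beyond the scatter). The reverse direction, a directly attached ring giving way to a ring on a methylene, would therefore be read as a rise. Yet from compound 1 to compound 3, where a directly attached pyridin-2-yl replaces the (thiophen-2-yl)methyl, a number 9.9 percentage points lower from compound 1 to compound 3 (within the scatter), so the same kind of change once stayed within the scatter.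

Taking both together, a small rise at most is expected: a number 6.3 percentage points higher from compound 3 to compound 4 (within the scatter). Compound 4 is estimated at 50%, between 30% and 70%.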

Compound 4, a percentage reported as inhibition, at one concentration (the size of the read-out at that concentration, not a potency): 40%
The estimate for compound 4 lay 10 percentage points above the measured number; the range from low to high includes it.
By their numbers in this assay, from the lowest: compound 2; then compounds 4, 3 and 1 (each within the scatter of the next, the first and the last beyond it).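

Going by these compounds alone, the extra methylene on the amide-type nitrogen can now be read on its own for the first time: in this assay, adding it to the pyridin-2-yl group gives a number 3.7 percentage points lower from compound 3 to compound 4 (within the scatter), so this change alone does not separate the two compounds. With the methylene kept, the ring can also be compared directly, and pyridin-2-yl in place of thiophen-2-yl gives a number 13.6 percentage points lower from compound 1 to compound 4 (beyond the scatter), while the change from a directly attached phenyl to (pyridin-2-yl)methyl gives a number 19.8 percentage points higher from compound 2 to compound 4 (beyond the scatter), so here the identity of the ring matters more than the added methylene does. Nothing available explains any of these steps.

As far as these compounds go, whether the methylene is equally silent with a phenyl ring stays open, since a benzyl group on this nitrogen would pair with compound 2 just as compound 4 pairs with compound 3. Also open, from the compounds shown here alone, is how a longer chain ahead of the pyridine ring, or an amine or a carboxylic acid on that ring, would read in this assay.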